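Trifluoromethyl on compound 1: expected step

The compounds below may be only part of what the source reports. "The series", "measured", "known", "first", "only" and "open" are said of these compounds alone.

In a functional assay on 786-0 cells (Homo sapiens) for cytotoxicity, read by sulforhodamine B assay, with a stated time of 48 h (a higher number here means that more compound is tolerated, a lower number that less compound is tolerated), compound 1 (`Nc1c(C(=O)Nc2ccccc2)sc2nc3c(cc12)CCCCCC3`) gives 10200 nM and compound 2 (`Nc1c(C(=O)Nc2ccccc2Cl)sc2nc3c(cc12)CCCCCC3`) gives 6120 nM; these two numbers lie within the scatter of each other, so compound 1 holds no separate place. Compound 3 (`Nc1c(C(=O)Nc2cccc(C(F)(F)F)c2)sc2nc3c(cc12)CCCCCC3`) is unmeasured and differs from compound 1 by trifluoromethyl in place of hydrogen on an aromatic carbon. Within the data shown here, the one measured step bearing on it, a 1.7-fold lower number from compound 1 to compound 2 (0.22 log units; within the scatter), is also a replacement of hydrogen on an aromatic carbon. Among the measured compounds shown here, with only that step as a guide, little change beyond the scatter is expected, leaning towards a lower number. The estimated step runs a 1.4-fold lower number from compound 1 to compound 3 (0.13 log units; within the scatter). For compound 3 the estimated value is 7500 nM, with an expected range of 3500 nM to 15000 nM.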

Compound 3, concentration lethal to 50% of the cells: 6070 nM
Estimate against measurement, compound 3: 1.2-fold (0.09 log units) above; the measured number falls inside the stated range.
By their numbers in this assay, from the lowest: compounds 3, 2 and 1 (each within the scatter of the next).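

In this assay, trifluoromethyl meta to a large group on the six-membered aromatic ring gives a 1.7-fold lower number from compound 1 to compound 3 (0.23 log units; within the scatter) and so stays within the scatter. Among these compounds, this is the first substituent of 4 heavy atoms seen on this ring, and the series so far shows no step beyond the scatter from replacing hydrogen on an aromatic carbon. No evidence is available that bears on this result. On these data alone, whether an amine or a carboxylic acid at this same place would also stay within the scatter remains open. Also open, as far as these compounds go, is whether a longer chain on the shared core would give a step beyond it.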